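From formyl to hydroxymethyl on a shared core

This account rests on a few compounds, and the source may have more. Where it says the series, first, only, none or still open, it means among the compounds named here.

In a functional assay on the whole organism with Mus musculus as the target (a lower number here means that less compound is needed, a higher number that more compound is needed for the effect), compound 1 `CN(c1ccncc1)n1cccc1Cl` gives > 20 mg/kg, which is a limit and not a number. Compound 2 `CN(c1ccncc1)n1cccc1C=O` gives > 20 mg/kg, which is also only a limit. For the measured compounds named here, the one measured step is a step that the two limits leave unreadable from compound 1 to compound 2, and the evidence is thin: the limit of > 20 mg/kg in this assay, at which 2 of the 2 values shown sit. Compound 3 `CN(c1ccncc1)n1cccc1CO` has hydroxymethyl in place of formyl on an aromatic carbon. Going by the values given here, no measured step gives a size or direction to carry over, so the expectation is that activity stays weak. The expected step is a step that the limit leaves unreadable from compound 2 to compound 3. For compound 3 the estimate is 30 mg/kg, with an expected range of 10 mg/kg to 60 mg/kg.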

Compound 3, dose for half-maximal effect: > 20 mg/kg
Compound 3 was reported as a limit (the forecaster's own chance of this, stated with the estimate: 75%); the middle value lies beyond the limit too.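

No step between compound 1, compound 2 and compound 3 can be read, because each result is a limit and not a number: the limit of > 20 mg/kg in this assay, at which 3 of the 3 values shown sit.

Going by these compounds, whether chloro, formyl and hydroxymethyl differ at all in the dose needed stays open.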